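Compound 2 to compound 3: longer amine side chain

The source may hold more compounds than are shown below. What is called first, only, known or untested is meant among the compounds shown, and "the series" means these compounds.

Compound 1 `O=S(=O)(c1ccc([C@H]2CC[C@]3(CC2)OOC2(O3)C3CC4CC(C3)CC2C4)cc1)N1CCNCC1` in an ADME assay on microsomes from liver (Homo sapiens) for metabolic stability, read by LC-MS, tested at 1 uM (on this read-out lower numbers stand for slow clearance and higher numbers for fast clearance), gives 16 mL.min-1.g-1
Compound 2 `NCCCOc1ccc([C@H]2CC[C@]3(CC2)OOC2(O3)C3CC4CC(C3)CC2C4)cc1` in this assay gives < 7 mL.min-1.g-1

Compound 2 gives no number, only (the limit of < 7 mL.min-1.g-1 in this assay, at which 1 of the 2 values shown sits). Compound 3 `c1cc([C@H]2CC[C@]3(CC2)OOC2(O3)C3CC4CC(C3)CC2C4)ccc1OCCOC1CCNCC1` differs from compound 2 as follows: (piperidin-4-yl)oxy in place of aminomethyl on a saturated chain carbon, two bonds along the chain from an oxygen on an aromatic ring. The 3-aminopropoxy group thus becomes 2-((piperidin-4-yl)oxy)ethoxy.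

Among the measured compounds shown here, one measured step bears on this, and only indirectly: an at least 2.2-fold lower number from compound 1 to compound 2 (0.35 log units; beyond the scatter). That step replaced a different group, and its size is known only as a bound, so it gives no direct measure for the new change. The step in this assay is expected to be small and, if it shows at all, towards higher numbers. No step beyond the scatter remains the likeliest outcome. For compound 3 the expected value is 8 mL.min-1.g-1, with an estimated range of 4 mL.min-1.g-1 to 18 mL.min-1.g-1. The estimated step is an at least 1.1-fold higher number from compound 2 to compound 3 (0.05 log units; that floor lies within the scatter).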

Compound 3, intrinsic clearance in microsomes: < 7 mL.min-1.g-1
Compound 3: no number, only a limit; the forecaster's own chance of this, stated with the estimate: 45%; at least 1.1-fold (0.05 log units) between middle value and limit.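

On the reading of this assay, replacing (piperazin-1-yl)sulfonyl on an aromatic carbon with 2-((piperidin-4-yl)oxy)ethoxy gives an at least 2.2-fold lower number from compound 1 to compound 3 (0.35 log units; beyond the scatter), so the lower reading is not confined to the 3-aminopropoxy group of compound 2. The step between compound 2 and compound 3 cannot be read, since neither compound gives a number, but the added ring and ether oxygen do not lift compound 3 to a measurable number in this assay. The result for compound 3 is a limit of the assay, and it joins compound 2 there: the limit of < 7 mL.min-1.g-1 in this assay, at which 2 of the 3 values shown sit.

From the compounds shown here alone, how far compound 2 and compound 3 lie beyond this limit remains open, and the two cannot be ordered. Also open, going by these compounds, is whether a morpholine or a carboxylic acid at the end of the same chain would stay at this limit.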